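Triazolopyrimidine series: amide to methylamine at the ring nitrogen

A few compounds are considered here, and "the series" means these few. Any claim that something is new, unique, unknown or untested is made for them only; others in the source may bear on it.

Measured so far:
compound 1, `COc1ccc(C(=O)Nc2nc(-c3ccccc3)nc3c2nnn3Cc2ccccc2F)cc1`: 21900000 nM
compound 2, `FC(F)(F)c1ccccc1Cn1nnc2c(NC3CCCC3)nc(-c3ccccc3)nc21`: 600000 nM

In an assay on isolated protein for binding affinity to adenosine receptor A1 (Bos taurus) (on this read-out higher numbers stand for weaker inhibition and lower numbers for stronger inhibition), compound 1 gives 21900000 nM, the highest of the two numbers recorded. Among the measured compounds shown here, compound 2 gives 600000 nM in this assay, and the gap between the two lies beyond the scatter; no single-point step connects them, so the comparison shows only that compound 1 is the weaker binder of the pair.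

Compound 3, `CNc1nc(-c2ccccc2)nc2c1nnn2Cc1ccccc1F`, has not yet been measured in this assay. It differs from compound 1 by methyl in place of (4-methoxyphenyl)carbonyl on a nitrogen on an aromatic ring.

For the measured compounds named here, with no measured step of this kind available, the expectation rests on compound 2, whose value 600000 nM shows that a small amino substituent at this position of the shared core is compatible with binding weaker than the amide of compound 1. A step of moderate size towards stronger binding is expected, an 11-fold lower number from compound 1 to compound 3 (1.04 log units; beyond the scatter). For compound 3 the expected value in this assay is 2000000 nM, within 300000 nM to 15000000 nM.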

Compound 3, inhibition constant: 25000000 nM
The estimate for compound 3 lay 13-fold (1.10 log units) below the measured number; the measured number lies above the stated range.
By their numbers in this assay, from the lowest: compound 2; then compounds 1 and 3 (each within the scatter of the next).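

In this assay, methyl in place of (4-methoxyphenyl)carbonyl on a nitrogen on an aromatic ring gives a 1.1-fold higher number from compound 1 to compound 3 (0.06 log units; within the scatter). On this pair, the whole (4-methoxyphenyl)carbonyl group, with its six-membered aromatic ring and carbonyl, can give way to a single methyl with no change in the number that stands clear of the scatter. No available evidence bears on why this exchange leaves the read-out unresolved.

As far as these compounds go, it remains open whether an unsubstituted amine, a longer chain such as propyl, or a small acyl group such as acetyl on this nitrogen would move the number beyond the scatter. Among the compounds shown here, what underlies the value of compound 2, 600000 nM, also stays open, as no single-place step reaches it.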